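Fluoro in place of bromo: notes on the series

The compounds below may be only part of what the source reports. "The series", "measured", "known", "first", "only" and "open" are said of these compounds alone.

Going by the values given here, in a functional assay on DLA cells (Mus musculus) for cytotoxicity, read by LDH release, with a stated time of 48 h (on this read-out higher numbers stand for weaker inhibition and lower numbers for stronger inhibition), compound 1 `Cc1ccc(OCC(=O)NNC(=O)c2cc3ccccc3oc2=O)c(C(=O)c2ccccc2Cl)c1` gives 54400 nM and compound 2 `Cc1ccc(OCC(=O)NNC(=O)c2cc3ccccc3oc2=O)c(C(=O)c2ccc(Br)cc2)c1` gives 95300 nM, so compound 2 stands level with its only measured neighbour, within the scatter. Compound 3 `Cc1ccc(OCC(=O)NNC(=O)c2cc3ccccc3oc2=O)c(C(=O)c2ccc(F)cc2)c1` differs from compound 2 by fluoro in place of bromo on an aromatic carbon, para to a large group. Among the compounds with values here, the one measured step that bears on this change, a 1.8-fold higher number from compound 1 to compound 2 (0.24 log units; within the scatter), also exchanges a halogen-carrying aryl group and stays within the scatter. No step beyond the scatter is therefore expected in this assay. The estimated step, a 1.4-fold lower number from compound 2 to compound 3 (0.13 log units; within the scatter), reflects this. For compound 3 the estimated value is 70000 nM, with an expected range of 32000 nM to 150000 nM.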

Compound 3, half-maximal inhibitory concentration: 45700 nM
Beside the measured number, compound 3's estimate is 1.5-fold (0.19 log units) above it, within the range that was stated.
By their numbers in this assay, from the lowest: compounds 3, 1 and 2 (each within the scatter of the next, the first and the last beyond it).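

In this assay, a halogen exchange on an aromatic carbon, para to a large group, now gives a step beyond the scatter, though a modest one: (a 2.1-fold lower number from compound 2 to compound 3 (0.32 log units; beyond the scatter)). Set against the 2-chlorophenyl group, the 4-fluorophenyl group gives no separation (a 1.2-fold lower number from compound 1 to compound 3 (0.08 log units; within the scatter)), so compound 1 lies within the scatter of both compound 2 and compound 3. Nothing shown here accounts for the step. As far as these compounds go, whether chloro, methoxy or an amine in the same place would read with fluoro, with bromo or apart from both remains open.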